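The source may report more compounds than this note shows. Statements on the series, on what has been measured and on what is new or still open speak of the compounds shown alone.

Working notes on the series.

Compound 1 `COc1cc(/C=N/Nc2nc(-c3ccccc3)cs2)c(Br)c(Br)c1OC` is the reference point. In a functional assay on A549 cells (Homo sapiens) for inhibition, read by MTT assay, with a stated time of 48 h (on this read-out lower numbers stand for stronger inhibition and higher numbers for weaker inhibition), compound 1 gives 15300 nM, the lowest of the two numbers obtained so far. The nearest measured neighbour is compound 2 `COc1cc(/C=N/Nc2nc(-c3ccccc3)cs2)cc(Br)c1OC`, which in this assay gives 40000 nM; the change from compound 1 to compound 2 is hydrogen in place of bromo on an aromatic carbon, and it reads as a 2.6-fold higher number from compound 1 to compound 2 (0.42 log units; beyond the scatter). Compound 3 `Fc1ccc(/C=N/Nc2nc(-c3ccc(Br)cc3)cs2)cc1F` belongs to the same series but carries a different aldehyde part and a bromo on the other ring. For compound 3 the assay returns only a limit, > 100000 nM, not a number; this is the limit of > 100000 nM in this assay, at which 1 of the 3 values shown sits.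

The next step goes from compound 1 to compound 4 `COc1cc(/C=N/Nc2nc(-c3ccc(C(F)(F)F)cc3)cs2)c(Br)c(Br)c1OC`. The structural change is trifluoromethyl in place of hydrogen on an aromatic carbon. Among the measured compounds shown here, no measured step touches this position: the single step available, from compound 1 to compound 2, concerns a bromo on the other ring, and compound 3 differs from compound 1 in more than one place, so its limit gives no direct guidance. For the measured compounds named here, with no comparable step to lean on, the expectation is for no step beyond the scatter, with a modest shift in either direction remaining possible; the expected step is a 1.0-fold lower number from compound 1 to compound 4 (0.01 log units; within the scatter). Compound 4 is therefore estimated at 15000 nM, with a range from 5000 nM to 45000 nM.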

Compound 4, half-maximal inhibitory concentration: 17600 nM
The estimate for compound 4 lay 1.2-fold (0.07 log units) below the measured number; low and high end bracket the measured number.
By their numbers in this assay, from the lowest: compounds 1 and 4 (each within the scatter of the next); then compound 2. At a limit, above all of these: compound 3.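

Among the compounds shown here, the step of a 1.2-fold higher number from compound 1 to compound 4 (0.06 log units; within the scatter) is the first reading at this position, and it shows that in this assay phenyl can be replaced by 4-(trifluoromethyl)phenyl without a difference beyond the scatter. The earlier series offered only a 2.6-fold higher number from compound 1 to compound 2 (0.42 log units; beyond the scatter), a change on the other ring, so the present result adds a site on the series where a substituent on an aromatic carbon, para to a large group, leaves the number within the scatter of that of the reference compound. Nothing in the evidence at hand bears on this result, and the step stands as an observation without an explanation.

One substituent at one position does not define what this site will tolerate: an amine, a carboxylic acid or a longer chain in the same place could read quite differently from trifluoromethyl. As far as these compounds go, it also remains open whether the same replacement would give a step of similar size on the background of compound 2, which carries one bromo fewer, since the two changes have not been seen together in a single compound here.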